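The source may report more compounds than this note shows. Statements on the series, on what has been measured and on what is new or still open speak of the compounds shown alone.

Compound 1 `CCCC(=O)OCSc1ccccc1C(=O)NCCCCNC(C)=O`: 17.4 uM
Compound 2 `CCCC(=O)OCSc1ccccc1C(=O)N[C@@H]1CCC[C@H]1C(N)=O`: 43.7 uM
Compound 3 `CCCC(=O)OCSc1ccccc1C(N)=O`: 12.4 uM

These three share one core and differ only in the group on the amide-type nitrogen. In an ADME assay on CEM-SS cells (Homo sapiens) for cytotoxicity, read by XTT assay, with a stated time of 6 days (a lower number here means that less compound is tolerated, a higher number that more compound is tolerated), compound 1 stands second highest of the three numbers: compound 3 is nearest, at a distance within the scatter (a 1.4-fold lower number from compound 1 to compound 3 (0.15 log units; within the scatter)), and compound 2 is furthest (a 2.5-fold higher number from compound 1 to compound 2 (0.40 log units; beyond the scatter)). Compound 4 `CCCC(=O)OCSc1ccccc1C(=O)NCC(=O)NCC(=O)OC` has not yet been measured. It differs from compound 1 by ((methoxycarbonyl)methyl)carbamoyl in place of 3-acetamidopropyl on a saturated chain carbon bound to an amide-type nitrogen. Among the compounds with values here, no measured step reworks the chain in this way; the closest comparisons are the swaps of the whole group on the amide-type nitrogen, a 2.5-fold higher number from compound 1 to compound 2 (0.40 log units; beyond the scatter) and a 3.5-fold lower number from compound 2 to compound 3 (0.55 log units; beyond the scatter), both modest. A step of about a 1.1-fold higher number from compound 1 to compound 4 (0.06 log units; within the scatter) is therefore expected, essentially no change beyond the scatter. Compound 4 is estimated at 20 uM, within 8 uM to 50 uM.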

Compound 4, half-maximal toxic concentration: > 100 uM
Compound 4 was reported as a limit; the forecaster's own chance of this, stated with the estimate: 10%; middle value at least 5.0-fold (0.69 log units) from the limit.
By their numbers in this assay, from the lowest: compounds 3 and 1 (each within the scatter of the next); then compound 2. At a limit, above all of these: compound 4.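

In this assay, ((methoxycarbonyl)methyl)carbamoyl in place of 3-acetamidopropyl gives an at least 5.7-fold higher number from compound 1 to compound 4 (0.75 log units; beyond the scatter). So a change on a saturated chain carbon bound to an amide-type nitrogen, with no ring in either group, can move this number beyond the scatter. The reading for compound 4 is a limit of the assay, not a number: the limit of > 100 uM in this assay, at which 1 of the 4 values shown sits.

The compounds shown do not separate the carbamoyl from the methoxycarbonyl, as both arrive together. On these data alone, how a carboxylic acid in place of the methoxycarbonyl, or a longer chain, would read remains open.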